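From cyclopropyl to 2-(dimethylamino)ethyl on an amide-type nitrogen

A few compounds are considered here, and "the series" means these few. Any claim that something is new, unique, unknown or untested is made for them only; others in the source may bear on it.

In a functional assay on A549 cells (Homo sapiens) for cytotoxicity, read by MTT assay, with a stated time of 72 h (on this read-out lower numbers stand for stronger inhibition and higher numbers for weaker inhibition), compound 1 `COc1ncc(-c2ccc3nc(NC(=O)N(C)C)nn3c2)cc1NS(=O)(=O)c1ccc(F)cc1` gives 1190 nM, compound 2 `COc1ncc(-c2ccc3nc(NC(=O)NCCN4CCCC4)nn3c2)cc1NS(=O)(=O)c1ccc(F)cc1` gives 960 nM, and compound 3 `COc1ncc(-c2ccc3nc(NC(=O)NC4CC4)nn3c2)cc1NS(=O)(=O)c1ccc(F)cc1` gives 210 nM, the lowest of the three numbers. Compound 4 `COc1ncc(-c2ccc3nc(NC(=O)NCCN(C)C)nn3c2)cc1NS(=O)(=O)c1ccc(F)cc1` has 2-(dimethylamino)ethyl in place of the cyclopropyl of compound 3 on an amide-type nitrogen (2-(dimethylamino)ethyl in place of cyclopropyl on an amide-type nitrogen). The entering chain resembles the 2-(pyrrolidin-1-yl)ethyl group of compound 2. The closest evidence is a 4.6-fold lower number from compound 2 to compound 3 (0.66 log units; beyond the scatter), a modest step beyond the scatter. Similarly, a 5.7-fold lower number from compound 1 to compound 3 (0.75 log units; beyond the scatter) is modest, while a 1.2-fold lower number from compound 1 to compound 2 (0.09 log units; within the scatter) stays within the scatter. A modest rise is therefore expected, a 3.8-fold higher number from compound 3 to compound 4 (0.58 log units; beyond the scatter). The estimate for compound 4 is 800 nM, with an expected range of 320 nM to 2000 nM.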

Compound 4, half-maximal inhibitory concentration: 800 nM
Estimate against measurement, compound 4: no gap at the digits printed, within the range that was stated.
By their numbers in this assay, from the lowest: compound 3; then compounds 4, 2 and 1 (each within the scatter of the next).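

In this assay, the cyclopropyl on this amide-type nitrogen now stands apart from a second amine-bearing chain, with 2-(dimethylamino)ethyl giving a 3.8-fold higher number from compound 3 to compound 4 (0.58 log units; beyond the scatter). The two chains cannot be told apart, with dimethylamino in place of pyrrolidin-1-yl giving a 1.2-fold lower number from compound 2 to compound 4 (0.08 log units; within the scatter), and compound 4 also stays within the scatter of the simple urea compound 1, at a 1.5-fold lower number from compound 1 to compound 4 (0.17 log units; within the scatter). No measurement shown here explains the cyclopropyl result.

From the compounds shown here alone, whether a plain ethyl or a cyclobutyl on this nitrogen would match compound 3 remains open.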